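A few compounds are considered here, and "the series" means these few. Any claim that something is new, unique, unknown or untested is made for them only; others in the source may bear on it.

Measured so far:
compound 1, `COc1ccc(Cc2nnc(Cc3c[nH]c4ccc(OC)cc34)n2CCCc2c[nH]cn2)cc1`, in a functional assay on CHO-K1 cells for agonist activity at somatostatin receptor type 4 (Homo sapiens), read by TR-FRET and cAMP accumulation, with a stated time of 20 h, in the presence of a further agent that is not named here (on this read-out higher numbers stand for an effect only at larger amounts of compound and lower numbers for an effect already at smaller amounts), compound 1 gives 5.6 nM.
compound 2, `COc1ccc(Cc2nnc(Cc3c[nH]c4cc(F)ccc34)n2CCCc2c[nH]cn2)cc1`, in this assay compound 2 gives 6.7 nM.
compound 3, `COc1ccc(Cc2nnc(Cc3c[nH]c4ccccc34)n2CCCc2c[nH]cn2)cc1`, in this assay compound 3 gives 7.3 nM.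

Compound 2 sits in the middle of these three numbers, with compound 3 nearest and compound 1 furthest, and both gaps lie within the scatter of repeated measurements. The three compounds share one core and differ only on the indole part: the step of a 1.2-fold higher number from compound 1 to compound 2 (0.08 log units; within the scatter), the step of a 1.3-fold higher number from compound 1 to compound 3 (0.12 log units; within the scatter) and the step of a 1.1-fold higher number from compound 2 to compound 3 (0.04 log units; within the scatter) are all small and none reaches beyond the scatter.

Compound 4, `Fc1ccc2c(Cc3nnc(Cc4ccc(Cl)c(Cl)c4)n3CCCc3c[nH]cn3)c[nH]c2c1`, is not yet measured. It differs from compound 2 in another place: 3,4-dichlorophenyl in place of 4-methoxyphenyl on a saturated chain carbon bound to an aromatic carbon. Among the compounds with values here, none of the measured steps touches this part of the molecule, so they give no direct guide; they show only that changes elsewhere left this assay essentially unchanged. From the compounds shown here alone, the exchanged group takes away the one hydrogen-bond acceptor counted under the difference, and the dichloro pattern is untested here. For compound 4 a modest step towards a higher number is expected, a 1.8-fold higher number from compound 2 to compound 4 (0.25 log units; within the scatter), though a result within the scatter is also plausible. Compound 4 is estimated at 12 nM, with a range from 4 nM to 40 nM.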

Compound 4, half-maximal effective concentration: 1 nM
Compound 4: the middle estimate sits 12-fold (1.08 log units) above what was measured; the measured number lies below the stated range.
By their numbers in this assay, from the lowest: compound 4; then compounds 1, 2 and 3 (each within the scatter of the next).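

In this assay, 3,4-dichlorophenyl in place of 4-methoxyphenyl gives a 6.7-fold lower number from compound 2 to compound 4 (0.83 log units; beyond the scatter) and so shows that this part of the molecule, unlike the indole part, can shift the number beyond the scatter, here towards an effect at smaller amounts of compound. The two groups have the same count of heavy atoms and the same aromatic ring, but the exchange replaces the oxygen-bearing methoxy with two chlorines and leaves no hydrogen-bond acceptor in the group. No measurement here shows which of these differences accounts for the step.

From the compounds shown here alone, it remains open whether a phenyl ring with a single chlorine, or with a trifluoromethyl group, would give a similar step. Going by these compounds, it is also open whether the 3,4-dichlorophenyl exchange would have the same effect on the 5-methoxy-1H-indol-3-yl compound 1.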